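A few compounds are considered here, and "the series" means these few. Any claim that something is new, unique, unknown or untested is made for them only; others in the source may bear on it.

Working notes on the series. Compound 1 `Cn1cnnc1SCC(=O)N/N=c1/scc(-c2ccc(C#N)cc2)n1-c1ccccc1` and compound 2 `O=C(CSc1nnnn1-c1ccccc1)N/N=c1/scc(-c2ccccc2)n1-c1ccccc1` were tested in a functional assay on C6 cells (Rattus norvegicus) for cytotoxicity, read by MTT assay, with a stated time of 24 h, tested at 50 ug/mL; a higher number here means a weaker effect of the compound at the concentration tested, a lower number a stronger effect. Compound 1 gives 58.8%; compound 2 gives 36.7%, the lowest of the two numbers, and the gap to compound 1 lies beyond the usual scatter. Compound 3 `N#Cc1ccc(-c2cs/c(=N/NC(=O)CSc3nnnn3-c3ccccc3)n2-c2ccccc2)cc1` is the next member and differs from compound 2 by cyano in place of hydrogen on an aromatic carbon. Compound 1 also carries a cyano group, although it differs from compound 2 in more than one place, so the expected step of a number 9.3 percentage points higher from compound 2 to compound 3 (within the scatter) is a modest rise, around the edge of the scatter. For compound 3 the estimate in this assay is 46%, within 30% to 62%.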

Compound 3, a percentage reported as activity, at one concentration (the size of the read-out at that concentration, not a potency): 61.1%
Compound 3: the middle estimate sits 15.1 percentage points below what was measured; the range from low to high includes it.
By their numbers in this assay, from the lowest: compound 2; then compounds 1 and 3 (each within the scatter of the next).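

Placing cyano on the aromatic carbon para to a large group, phenyl to 4-cyanophenyl, gives a number 24.4 percentage points higher from compound 2 to compound 3 (beyond the scatter) in this assay and so weakens the effect at the concentration tested, showing that this position responds to the change. With 4-cyanophenyl held constant, 1-phenyl-1H-tetrazol-5-yl in place of 4-methyl-4H-1,2,4-triazol-3-yl on the sulfur gives a number 2.3 percentage points higher from compound 1 to compound 3 (within the scatter) and does not separate the two groups. No measurement available here accounts for the cyano step. As far as these compounds go, whether an amine or a methoxy group at this position would move the number as cyano does remains open. Also open, from the compounds shown here alone, is whether the sulfur-linked groups would stay this close on the unsubstituted phenyl.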